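Cyclopropyl in Place of Furan-3-yl at the Amide Carbonyl

A few compounds are considered here, and "the series" means these few. Any claim that something is new, unique, unknown or untested is made for them only; others in the source may bear on it.

Measured so far in an assay (strain Wistar) for displacement of a labelled ligand from adenosine receptor A1 (Rattus norvegicus), read by scintillation counting; a higher number here means a weaker inhibitor, a lower number a stronger inhibitor:
compound 1, `O=C(Nc1nc(-c2ccccc2)nc2c1nnn2Cc1ccccc1)c1ccc(Cl)cc1`: 108 nM
compound 2, `O=C(Nc1nc(-c2ccccc2)nc2c1nnn2Cc1ccccc1)c1ccoc1`: 10 nM
compound 3, `CCOc1ccccc1C(=O)Nc1nc(-c2ccccc2)nc2c1nnn2Cc1ccccc1`: 1850 nM

Compound 2 stands lowest of the three numbers in this assay. Its nearest neighbour is compound 1, separated by the step of an 11-fold lower number from compound 1 to compound 2 (1.03 log units; beyond the scatter); its furthest is compound 3, separated by the step of a 190-fold higher number from compound 2 to compound 3 (2.27 log units; beyond the scatter). The remaining measured pair, compound 1 and compound 3, differ by the step of a 17-fold higher number from compound 1 to compound 3 (1.23 log units; beyond the scatter).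

Compound 4, `O=C(Nc1nc(-c2ccccc2)nc2c1nnn2Cc1ccccc1)C1CC1`, has not yet been measured. It differs from compound 2 in one place: cyclopropyl in place of furan-3-yl on a carbonyl carbon.

All three measured steps change the group on the same carbonyl carbon, and each was large and beyond the scatter, so this position clearly governs the number in this assay. Within the data shown here, none of them, however, involves cyclopropyl, and no step separates a ring from a non-aromatic group here. Given that every departure from furan-3-yl so far moved the number upward, compound 4 is expected to sit above compound 2, by a step beyond the scatter but short of the largest seen. Compound 4 is therefore estimated at 50 nM, in the range 12 nM to 250 nM. This estimate means the step of a 5.0-fold higher number from compound 2 to compound 4 (0.70 log units; beyond the scatter) is expected.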

Compound 4, inhibition constant: 7.5 nM
Beside the measured number, compound 4's estimate is 6.7-fold (0.82 log units) above it; the whole stated range lies above it.
By their numbers in this assay, from the lowest: compounds 4 and 2 (each within the scatter of the next); then compound 1; then compound 3.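

In this assay, cyclopropyl on the carbonyl carbon reads level with furan-3-yl (a 1.3-fold lower number from compound 2 to compound 4 (0.12 log units; within the scatter)), so among these compounds an aromatic ring is not required at this position, nor is the hydrogen-bond acceptor that furan-3-yl carries. The separation from the substituted phenyl groups is wide on both sides (a 14-fold lower number from compound 1 to compound 4 (1.16 log units; beyond the scatter); a 250-fold lower number from compound 3 to compound 4 (2.39 log units; beyond the scatter)), so furan-3-yl no longer stands alone at the low end of the series, and the non-aromatic cyclopropyl now shares that place. Nothing available here accounts for why these two different groups read alike.

Going by these compounds, it remains open whether an open chain such as isopropyl or a longer alkyl chain would read like cyclopropyl. Also open, on these data alone, is how unsubstituted phenyl or a larger saturated ring such as cyclohexyl would compare.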